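This account rests on a few compounds, and the source may have more. Where it says the series, first, only, none or still open, it means among the compounds named here.

Measured so far in a functional assay on HT-29 cells (Homo sapiens) for cytotoxicity, read by MTT assay, with a stated time of 2 days, tested at 10 uM; a higher number here means more inhibition at the concentration tested (going by the name of the read-out), a lower number less inhibition:

Compound 1 `Cc1cccc(N2CCN(CCCCNc3nc(NCc4ccco4)c4cc(F)ccc4n3)CC2)c1C` gives 96.1%.
Compound 2 `Cc1cccc(N2CCN(CCCCNc3nc(NCc4ccco4)c4ccccc4n3)CC2)c1C` gives 94.2%.
Compound 3 `CCN(CC)CCNc1nc(NCc2ccco2)c2cc(F)ccc2n1` gives 27.5%.

Compounds 1 and 2 share one core and differ by hydrogen in place of fluoro on an aromatic carbon; that change moved the read-out by a number 1.9 percentage points lower from compound 1 to compound 2 (within the scatter). Compound 3 carries a different side chain on the shared core, and the difference between the two cores is not broken down here; its value falls well below those of compound 1 and compound 2.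

Compound 4 `CCN(CC)CCNc1nc(NCc2ccco2)c2ccccc2n1` is not yet measured. It stands to compound 3 as compound 2 stands to compound 1, by the same change, (hydrogen in place of fluoro on an aromatic carbon). Because the earlier step of a number 1.9 percentage points lower from compound 1 to compound 2 (within the scatter) stayed within the scatter, the expected step from compound 3 to compound 4 is estimated at a number 1.5 percentage points lower from compound 3 to compound 4 (within the scatter). Compound 4 is therefore expected to give about 26% in this assay, likely between 10% and 45%.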

Compound 4, a percentage reported as inhibition, at one concentration (the size of the read-out at that concentration, not a potency): 75.1%
Beside the measured number, compound 4's estimate is 49.1 percentage points below it; measured number outside the range, above it.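

Putting hydrogen in place of fluoro gave, in this assay, a number 47.6 percentage points higher from compound 3 to compound 4 (beyond the scatter). The size of this change therefore depends on the core that carries it, so a step seen on one core cannot simply be carried over to the other in this series: the same change on two cores in this assay, a number 1.9 percentage points lower (within the scatter) from compound 1 to compound 2 and a number 47.6 percentage points higher (beyond the scatter) from compound 3 to compound 4, 49.5 percentage points apart, beyond the scatter of two such steps

This rests on one pair of compounds for each of two cores, and it does not show which part of the side chain makes the difference, or why. Left open is how the same change behaves with other side chains, such as a longer chain or a morpholine in place of the diethylamino group. Also open, on these data alone, is how another group, such as chloro or methoxy, behaves in place of fluoro.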